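The compounds below may be only part of what the source reports. "The series", "measured", "known", "first", "only" and "open" are said of these compounds alone.

Measured compounds:
- compound 1, `COC(=O)CNC(=O)c1ccc(OC[C@H]2COc3ccccc3O2)cc1-c1ccccc1C`, 27000 nM in a functional assay (HSMC cells, Homo sapiens) for antiproliferative activity, with a stated time of 72 h; on this read-out lower numbers stand for stronger inhibition and higher numbers for weaker inhibition
- compound 2, `COC(=O)[C@H](CC(C)C)NC(=O)c1ccc(OC[C@H]2COc3ccccc3O2)cc1-c1ccccc1C`, 3000 nM
- compound 3, `COC(=O)CNC(=O)c1ccc(C(=O)NC[C@H]2COc3ccccc3O2)cc1-c1ccccc1C`, 113000 nM

Compound 2 differs from compound 1 by isobutyl in place of hydrogen on a saturated chain carbon bound to an amide-type nitrogen and a carbonyl carbon. This change gave a 9.0-fold lower number from compound 1 to compound 2 (0.95 log units; beyond the scatter). Compound 3 carries a different core; the difference between the two cores is not broken down here. Compound 3 stands highest of the three measured numbers, and its gap to compound 1 is beyond the scatter.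

Compound 4, `COC(=O)[C@H](CC(C)C)NC(=O)c1ccc(C(=O)NC[C@H]2COc3ccccc3O2)cc1-c1ccccc1C`, has not yet been measured in this assay. It differs from compound 3 by isobutyl in place of hydrogen on a saturated chain carbon bound to an amide-type nitrogen and a carbonyl carbon, the same change that turns compound 1 into compound 2, at the same place. For the measured compounds named here, since the one earlier example of this change on a related core gave a 9.0-fold lower number from compound 1 to compound 2 (0.95 log units; beyond the scatter), a step of a similar size is expected here, with room for it to be somewhat smaller or larger on the core of compound 3. The step from compound 3 to compound 4 is estimated as a 7.5-fold lower number from compound 3 to compound 4 (0.88 log units; beyond the scatter). Compound 4 is therefore expected to give about 15000 nM, between 5000 nM and 50000 nM.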

Compound 4, half-maximal inhibitory concentration: 103000 nM
Compound 4: the middle estimate sits 6.9-fold (0.84 log units) below what was measured, and the stated range ends below it.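

In this assay, isobutyl in place of hydrogen on a saturated chain carbon bound to an amide-type nitrogen and a carbonyl carbon gave a 1.1-fold lower number from compound 3 to compound 4 (0.04 log units; within the scatter), so this change made no measurable difference on the core of compound 3. The drop in the number seen on the core of compound 1 therefore did not carry over to the core of compound 3: the same change on two cores in this assay, a 9.0-fold lower number (0.95 log units; beyond the scatter) from compound 1 to compound 2 and a 1.1-fold lower number (0.04 log units; within the scatter) from compound 3 to compound 4, 8.2-fold (0.91 log units) apart, beyond the scatter of two such steps. For the compounds shown here, with only one pair on each core, this shows that the size of the step depended on the core in these four compounds, but it does not show which part of the cores accounts for this or how the change would behave on any further core.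

The compounds shown leave open whether methyl or benzyl in place of isobutyl on that carbon would separate the two cores in the same way. They also leave open whether a carboxylic acid in place of the methyl ester would alter the picture on either core.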